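The compounds below may be only part of what the source reports. "The series", "measured", "known", "first", "only" and "open" are said of these compounds alone.

Measured so far:
- compound 1, `COc1ccc(NC(=O)C2(C(=O)Nc3ccc(Nc4ncc5cc(C(=O)N(C)C)n(C6CCCC6)c5n4)cc3)CC2)cc1`, 74.4%
- compound 2, `CN(C)C(=O)c1cc2cnc(Nc3ccc(NC(=O)C4(C(=O)Nc5ccccc5F)CC4)cc3)nc2n1C1CCCC1`, 79.1%
- compound 3, `COC(=O)c1cccc(NC(=O)C2(C(=O)Nc3ccc(Nc4ncc5cc(C(=O)N(C)C)n(C6CCCC6)c5n4)cc3)CC2)c1`, 10.5%

All three share one core and differ only in the aryl group on one amide-type nitrogen. In a functional assay on A549 cells (Homo sapiens) for inhibition, read by CCK-8 assay, with a stated time of 72 h, tested at 1 uM (on this read-out higher numbers stand for more inhibition of growth at the one concentration tested and lower numbers for less inhibition of growth), compound 2 gives the highest of the three numbers, but its gap to compound 1, a number 4.7 percentage points higher from compound 1 to compound 2 (within the scatter), lies within the scatter, so the two cannot be ranked; only compound 3 stands clearly apart, as a number 68.6 percentage points lower from compound 2 to compound 3 (beyond the scatter) and a number 63.9 percentage points lower from compound 1 to compound 3 (beyond the scatter) show.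

Compound 4, `CN(C)C(=O)c1cc2cnc(Nc3ccc(NC(=O)C4(C(=O)Nc5ccc(C(F)(F)F)cc5)CC4)cc3)nc2n1C1CCCC1`, is the next step from compound 2: 4-(trifluoromethyl)phenyl in place of 2-fluorophenyl on an amide-type nitrogen. Among the measured compounds shown here, the steps that bear on it point two ways. Swapping 4-methoxyphenyl for 2-fluorophenyl changed little, while 3-(methoxycarbonyl)phenyl cut growth inhibition sharply. The trifluoromethyl group is neither of these, so a drop of uncertain size is expected, a number 17.1 percentage points lower from compound 2 to compound 4 (beyond the scatter), with a wide range. The estimate for compound 4 in this assay is 62%, expected to fall between 25% and 85%.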

Compound 4, percent growth inhibition at one concentration: -25.3%
Compound 4: the middle estimate sits 87.3 percentage points above what was measured; measured number outside the range, below it.
By their numbers in this assay, from the lowest: compound 4; then compound 3; then compounds 1 and 2 (each within the scatter of the next).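

In this assay, the aryl group on this amide-type nitrogen proves able to do far more than lower growth inhibition modestly: 4-(trifluoromethyl)phenyl in place of 2-fluorophenyl gives a number 104.4 percentage points lower from compound 2 to compound 4 (beyond the scatter), and trifluoromethyl in place of methoxy on an aromatic carbon gives a number 99.7 percentage points lower from compound 1 to compound 4 (beyond the scatter). Compound 3 had looked like the low end of this series, yet 4-(trifluoromethyl)phenyl in place of 3-(methoxycarbonyl)phenyl still gives a number 35.8 percentage points lower from compound 3 to compound 4 (beyond the scatter), so compound 4 is now clearly the lowest of the four. No measurement at hand explains why this one group change has so large an effect.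

From the compounds shown here alone, it remains open how an amine or a carboxylic acid on this phenyl ring would read. Going by these compounds, whether a simple unsubstituted phenyl would sit with compounds 1 and 2 or with compounds 3 and 4 also remains open.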